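A few compounds are considered here, and "the series" means these few. Any claim that something is new, unique, unknown or untested is made for them only; others in the source may bear on it.

Measured compounds:
Compound 1 `N#Cc1c(O)nc(SCc2nc3ccccc3[nH]2)nc1-c1ccccc1`: 4.63 nM
Compound 2 `N#Cc1c(Cl)nc(SCc2nc3ccccc3[nH]2)nc1-c1ccccc1`: 11.3 nM
Compound 3 `CNc1nc(SCc2nc3ccccc3[nH]2)nc(-c2ccccc2)c1C#N`: 13.2 nM

In a functional assay on K562 cells (Homo sapiens) for cytotoxicity, read by MTT assay, with a stated time of 3 days (a higher number here means a weaker inhibitor, a lower number a stronger inhibitor), compound 3 gives 13.2 nM. It stands level with compound 2, as shown by a 1.2-fold higher number from compound 2 to compound 3 (0.07 log units; within the scatter), and apart from compound 1, as shown by a 2.9-fold higher number from compound 1 to compound 3 (0.45 log units; beyond the scatter). Compound 4 `CCNc1nc(SCc2nc3ccccc3[nH]2)nc(-c2ccccc2)c1C#N` has ethylamino where compound 3 has methylamino, which is methyl in place of hydrogen on a saturated chain carbon bound to a nitrogen on an aromatic ring. Within the data shown here, no measured step extends this chain. The nearest evidence is the two steps to compound 3 given above, one modest and one within the scatter, so no step beyond the scatter is expected for a single added methyl. The expected change is a 1.1-fold higher number from compound 3 to compound 4 (0.06 log units; within the scatter). Compound 4 is estimated at 15 nM, with an expected range of 7 nM to 32 nM.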

Compound 4, half-maximal inhibitory concentration: 4.38 nM
Beside the measured number, compound 4's estimate is 3.4-fold (0.53 log units) above it; the whole stated range lies above it.
By their numbers in this assay, from the lowest: compounds 4 and 1 (each within the scatter of the next); then compounds 2 and 3 (each within the scatter of the next).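

In this assay, among these compounds, a single added methyl on a saturated chain carbon bound to a nitrogen on an aromatic ring gives a 3.0-fold lower number from compound 3 to compound 4 (0.48 log units; beyond the scatter), so this position responds to a change of one carbon, which the earlier compounds did not show. Ethylamino also gives a 2.6-fold lower number from compound 2 to compound 4 (0.41 log units; beyond the scatter), whereas methylamino stood level with chloro. With a 1.1-fold lower number from compound 1 to compound 4 (0.02 log units; within the scatter), compound 4 stands level with compound 1, which methylamino did not do.

On these data alone, whether propylamino or a longer chain on the same nitrogen would hold this level remains open. Nothing available explains the effect of the added methyl.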